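The compounds below may be only part of what the source reports. "The series", "measured", "known", "first", "only" and "open" are said of these compounds alone.

Compounds measured so far:
- compound 1, `O=C(CCN1CCC(CCCn2c(COc3ccccc3)nc3c(OCCCN4CCCCC4)cccc32)CC1)c1ccccc1`: 0.112 nM
- compound 2, `C=CCN1CCC(CCCn2c(COc3ccccc3)nc3c(OCCCN4CCCCC4)cccc32)CC1`: 1.63 nM
- compound 3, `c1ccc(CCCN2CCC(CCCn3c(COc4ccccc4)nc4c(OCCCN5CCCCC5)cccc43)CC2)cc1`: 0.361 nM

All three were tested in an in vitro assay on AV12 cells for binding affinity to Neuropeptide Y receptor type 1 (Homo sapiens); a lower number here means a stronger inhibitor, a higher number a weaker inhibitor. Compound 3 stands second of the three, with compound 1 the nearest neighbour and compound 2 the furthest.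

Compound 4, `c1ccc(OCc2nc3c(OCCCN4CCCCC4)cccc3n2CCCC2CCNCC2)cc1`, has not yet been measured. It differs from compound 3 in one place: hydrogen in place of 3-phenylpropyl on an amine nitrogen in a ring.

Every measured step touches this same amine nitrogen in a ring. Going from compound 1 to compound 2 gave a 15-fold higher number from compound 1 to compound 2 (1.16 log units; beyond the scatter), from compound 1 to compound 3 a 3.2-fold higher number from compound 1 to compound 3 (0.51 log units; beyond the scatter), and from compound 2 to compound 3 a 4.5-fold lower number from compound 2 to compound 3 (0.65 log units; beyond the scatter). Each time the smaller group on that nitrogen gave the higher number, with the smallest group, vinyl, giving the weakest inhibitor. Among the measured compounds shown here, no measured compound carries hydrogen there, so the size of the step is uncertain, but a loss beyond the scatter is expected. Compound 4 is therefore estimated at 8 nM, in the range 2 nM to 40 nM, which means an expected step of a 22-fold higher number from compound 3 to compound 4 (1.35 log units; beyond the scatter).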

Compound 4, inhibition constant: 4.5 nM
Estimate against measurement, compound 4: 1.8-fold (0.25 log units) above; the range from low to high includes it.
By their numbers in this assay, from the lowest: compound 1; then compound 3; then compound 2; then compound 4.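

In this assay, the ring amine left with only hydrogen makes compound 4 the weakest inhibitor of the four, so each of the three groups carried on this nitrogen gives a lower number than hydrogen does. Hydrogen in place of 3-phenylpropyl gives a 12-fold higher number from compound 3 to compound 4 (1.10 log units; beyond the scatter), hydrogen in place of allyl gives a 2.8-fold higher number from compound 2 to compound 4 (0.44 log units; beyond the scatter), and hydrogen in place of 2-benzoylethyl gives a 40-fold higher number from compound 1 to compound 4 (1.60 log units; beyond the scatter), so even the allyl group, the smallest of the three, keeps a step beyond the scatter over hydrogen. No other data here explain this result.

Still open, on these data alone, is how a methyl or a plain propyl group on this nitrogen would compare with hydrogen and with allyl. A propyl group would also help show how much of the step from 3-phenylpropyl belongs to the chain and how much to its phenyl ring.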